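Sulfonamide Variations Against Mitochondrial Malate Dehydrogenase

The source may report more compounds than this note shows. Statements on the series, on what has been measured and on what is new or still open speak of the compounds shown alone.

Compound 1, `COc1ccccc1S(=O)(=O)Nc1ccc2oc(-c3ccccc3)nc2c1`: > 63000 nM
Compound 2, `COc1ccc(S(=O)(=O)Nc2ccc3oc(-c4ccccc4)nc3c2)cc1`: > 63000 nM
Compound 3, `COc1ccc(Cl)cc1S(=O)(=O)Nc1ccc2oc(-c3ccccc3)nc2c1`: > 63000 nM

Of the compounds shown here, three have been tested in an assay on isolated protein for inhibition of malate dehydrogenase, mitochondrial (Sus scrofa), with stated times of 45 min and 30 min; a higher number here means a weaker inhibitor, a lower number a stronger inhibitor. Compound 1 gives > 63000 nM, which is a limit of the assay rather than a number. Compound 2 likewise gives > 63000 nM, again a limit. Compound 3 gives > 63000 nM, also a limit. Compound 3 therefore stands exactly where the other two stand, at the limit of > 63000 nM in this assay, at which 3 of the 3 values shown sit, and none of the steps between them can be read: a step that the two limits leave unreadable from compound 1 to compound 2, a step that the two limits leave unreadable from compound 1 to compound 3 and a step that the two limits leave unreadable from compound 2 to compound 3 all run from one limit to another.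

The next compound is compound 4, `O=S(=O)(Nc1ccc2oc(-c3ccccc3)nc2c1)c1ccc(O)cc1`. It differs from compound 3 in one place: 4-hydroxyphenyl in place of 5-chloro-2-methoxyphenyl on a sulfonyl sulfur. Among the measured compounds shown here, two measured steps touch the same position on the sulfonyl sulfur, from compound 1 to compound 2 and from compound 2 to compound 3, and both are unreadable. So nothing measured points to a readable step in this assay in either direction. It is expected that compound 4, like compound 3, returns only a limit, so the expected step is a step that the limit leaves unreadable from compound 3 to compound 4. The estimate for compound 4 is 80000 nM, with a range from 20000 nM to 300000 nM.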

Compound 4, half-maximal inhibitory concentration: > 63000 nM
Compound 4 ended at the assay's limit (the forecaster's own chance of this, stated with the estimate: 75%); the middle value does not contradict the limit.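

In this assay compound 4 gives > 63000 nM, a limit of the assay. Its steps from compound 1, compound 2 and compound 3 therefore cannot be read, since all four compounds stand at the same limit: the limit of > 63000 nM in this assay, at which 4 of the 4 values shown sit. The compounds shown leave open whether any group on the sulfonyl sulfur would give a readable value in this assay.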